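Swapping an amide for an ester on the side chain

The source may hold more compounds than are shown below. What is called first, only, known or untested is meant among the compounds shown, and "the series" means these compounds.

In a functional assay on OVCAR-8 cells (Homo sapiens) for antiproliferative activity (on this read-out higher numbers stand for weaker inhibition and lower numbers for stronger inhibition), compound 2 `CC(=O)NCC[C@@H]1C[C@@H](c2ccc(F)c(F)c2)[C@H](NC(=O)c2cc(-c3c(Cl)cnn3C)c(Cl)o2)CN1` gives 880 nM as its value. Compound 1 `Cn1ncc(Cl)c1-c1cc(C(=O)N[C@@H]2CN[C@H](CCNS(C)(=O)=O)C[C@H]2c2ccc(F)c(F)c2)oc1Cl` gives 1530 nM and compound 3 `CN(C)CC[C@@H]1C[C@@H](c2ccc(Cl)c(Cl)c2)[C@H](NC(=O)c2cc(-c3c(Cl)cnn3C)c(Cl)o2)CN1` gives 1510 nM on the same read-out. The gap from compound 2 to each of these two lies within the usual scatter, so the three numbers do not separate it from its neighbours.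

Compound 4 `CC(=O)OCC[C@@H]1C[C@@H](c2ccc(F)c(F)c2)[C@H](NC(=O)c2cc(-c3c(Cl)cnn3C)c(Cl)o2)CN1` has not been measured yet. It carries acetoxy in place of acetamido on a saturated chain carbon, two bonds along the chain from a saturated ring carbon is the full count of that difference.

Among the compounds with values here, only one measured step bears on this. It is a 1.7-fold lower number from compound 1 to compound 2 (0.24 log units; within the scatter) and it also alters the group on the amine nitrogen. Within the data shown here, no measured step replaces that nitrogen, so the evidence is indirect. The estimated change is a 1.1-fold higher number from compound 2 to compound 4 (0.06 log units; within the scatter) and it is expected to stay within the scatter. The estimated value for compound 4 is 1000 nM with 400 nM to 2500 nM as the expected range.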

Compound 4, half-maximal inhibitory concentration: 4960 nM
Estimate against measurement, compound 4: 5.0-fold (0.70 log units) below, and the stated range ends below it.
By their numbers in this assay, from the lowest: compounds 2, 3 and 1 (each within the scatter of the next); then compound 4.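

In this assay, the linking atom on this side chain turns out to matter: a 5.6-fold higher number from compound 2 to compound 4 (0.75 log units; beyond the scatter) is a step beyond the scatter, so acetoxy on this saturated chain carbon is not an even trade for acetamido. The same holds against the sulfonamide side chain, as a 3.2-fold higher number from compound 1 to compound 4 (0.51 log units; beyond the scatter) is also beyond the scatter, whereas the earlier swap on the amine nitrogen, a 1.7-fold lower number from compound 1 to compound 2 (0.24 log units; within the scatter) stayed within it, so both nitrogen-linked groups sit apart from the ester. Nothing measured here explains why the ester gives the higher number.

The change replaces a nitrogen with an oxygen and takes hydrogen-bond donors from 1 to 0, and a single ester cannot tell these apart. A hydroxyl or a methyl ether on the same chain, or an acetamido with a methyl group on its nitrogen, remains an open comparison.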